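The source may report more compounds than this note shows. Statements on the series, on what has been measured and on what is new or still open speak of the compounds shown alone.

Measured compounds and their maximal responses:
- compound 1, `O=C(O)Cc1sc(C(c2ccc(F)cc2)c2ccc(F)cc2)nc1-c1ccnc(N2CCCC2)c1`: 80%
- compound 2, `O=C(O)Cc1sc(C(c2ccccc2)c2ccccc2)nc1-c1ccc(C(F)(F)F)cc1`: 80%
- compound 3, `COc1ccc(OC)c(-c2nc(C(c3ccccc3)c3ccccc3)sc2CC(=O)O)c1`: 80%

All three were tested in an in vitro functional assay on HEK285-7 cells for antagonist activity at prostaglandin D2 receptor 2 (Homo sapiens), read by BRET and beta-arrestin recruitment; on this read-out higher numbers stand for larger maximal responses and lower numbers for smaller maximal responses. Compound 1 stands level with compounds 2 and 3 at the digits shown, since its values do not differ beyond the usual scatter from either.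

The next compound, compound 4 `O=C(O)Cc1sc(C(c2ccc(F)cc2)c2ccc(F)cc2)nc1-c1cn[nH]c1`, differs from compound 1 by a single change, (1H-pyrazol-4-yl in place of 2-(pyrrolidin-1-yl)pyridin-4-yl on an aromatic carbon). Among the compounds with values here, the one measured step that bears on this is the exchange of the group at the same carbon between compound 2 and compound 3: no change at the digits printed from compound 2 to compound 3 (within the scatter). Within the data shown here, that swap of one aromatic group for another at this position left the maximal response unchanged within the scatter, which is the only guide here to what happens when the group at this carbon is altered. Among the measured compounds shown here, the change from compound 1 to compound 4 exchanges a larger group for a smaller one, and no measured pair shows that kind of change, so nothing points to a step in either direction.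

Compound 4 is therefore expected to give about 80% in this assay, within a range from 60% to 95%, meaning an estimated step of no change at the digits printed from compound 1 to compound 4 (within the scatter), which is no change beyond the scatter.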

Compound 4, largest response reached (reported as efficacy), in percent of the reference or control that the assay uses: 80%
Estimate against measurement, compound 4: no gap at the digits printed; measured number inside the range.
By their numbers in this assay, from the lowest: compounds 1, 2, 3 and 4 (each within the scatter of the next).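

Exchanging 2-(pyrrolidin-1-yl)pyridin-4-yl for 1H-pyrazol-4-yl, on the aromatic carbon next to the ring nitrogen, gives in this assay a result of no change at the digits printed from compound 1 to compound 4 (within the scatter). Within the data shown here, the earlier step at this carbon only replaced one substituted phenyl group with another, whereas this change goes from a group of 11 heavy atoms to one of 5, loses the pyrrolidine ring, and brings in a five-membered aromatic ring with a hydrogen-bond donor, so the maximal response holds across a much wider change in the group at this position than the earlier compounds covered. No measurement offered here explains why the response stays level.

With every compound level in this read-out, the compounds shown leave open whether any group at this carbon can shift the maximal response at all, for example a plain hydrogen, a small open-chain amine such as dimethylamino, or a 1-methylpyrazol-4-yl group, which would test whether the hydrogen on the pyrazole nitrogen matters. They also say nothing about the carboxymethyl group, where a longer chain such as a carboxyethyl group could be compared in a single step.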